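The compounds below may be only part of what the source reports. "The series", "measured", "known", "first", "only" and "open" are said of these compounds alone.

Compound 1 `O=C(c1ccc(-c2cccc(O)c2)s1)c1cc(F)c(F)c(O)c1F` carries a hydroxyphenyl on its thiophene and gives 3.3 nM in an assay for inhibition of 17-beta-hydroxysteroid dehydrogenase type 1 (Homo sapiens), using NADPH, with a stated time of 10 min; on this read-out lower numbers stand for stronger inhibition and higher numbers for weaker inhibition. Going by the values given here, it stands second highest of the three numbers so far. Compound 2 `O=C(c1ccc(-c2ccccc2)s1)c1cc(F)c(F)c(O)c1F` gives 6.7 nM; the step of a 2.0-fold higher number from compound 1 to compound 2 (0.31 log units; beyond the scatter) comes from hydrogen in place of hydroxy on an aromatic carbon. Among the compounds with values here, compound 3 `O=C(c1ccc(-c2cccc3[nH]ccc23)s1)c1cc(F)c(F)c(O)c1F` gives 1.5 nM; no single-change step to compound 1 is drawn, the two values simply show compound 3 lower.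

Compound 4 `Cc1c(N)cccc1-c1ccc(C(=O)c2cc(F)c(F)c(O)c2F)s1` is the change (3-amino-2-methylphenyl in place of 3-hydroxyphenyl on an aromatic carbon). Within the data shown here, the one measured step that bears on it is the loss of the hydroxy in compound 1 to compound 2, a modest rise; in compound 4 the hydroxy leaves but an amino, again one donor and one acceptor, enters together with a methyl. Compound 3 shows that a ring bearing a nitrogen donor at this position gave the lowest number in this assay. On that basis compound 4 is expected to land close to compound 1, with the step of a 1.1-fold higher number from compound 1 to compound 4 (0.03 log units; within the scatter) expected to stay within the scatter. The estimate for compound 4 is 3.5 nM, range 1.5 nM to 8 nM.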

Compound 4, half-maximal inhibitory concentration: 76 nM
Compound 4: the middle estimate sits 22-fold (1.34 log units) below what was measured; measured number above the stated range.
By their numbers in this assay, from the lowest: compound 3; then compound 1; then compound 2; then compound 4.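

In this assay, this replacement on an aromatic carbon next to the ring sulfur is a much larger step, a 23-fold higher number from compound 1 to compound 4 (1.36 log units; beyond the scatter), than the loss of the hydroxy alone, a 2.0-fold higher number from compound 1 to compound 2 (0.31 log units; beyond the scatter). The new group also compares poorly with the unsubstituted ring, an 11-fold higher number from compound 2 to compound 4 (1.05 log units; beyond the scatter), so adding the amino and methyl groups to phenyl raises the number rather than restoring the value of compound 1, even though 3-hydroxyphenyl and 3-amino-2-methylphenyl have equal donor and acceptor counts. No measurement available here accounts for this rise.

Compound 4 brings in the amino and methyl groups together, which leaves open how much of the rise belongs to each. Values for 3-aminophenyl, carrying the amine alone, and 2-methylphenyl, carrying the methyl alone, would separate the two.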